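The source may hold more compounds than are shown below. What is called first, only, known or untested is meant among the compounds shown, and "the series" means these compounds.

Measured so far in this series:
compound 1 `CCOC(=O)C1CCN(c2c(S(=O)(=O)c3ccccc3)cnc3ccccc23)CC1` — 33%
compound 2 `CC1CCN(c2c(S(=O)(=O)c3ccc(Cl)c(Cl)c3)cnc3cc(F)ccc23)CC1` — 94%
compound 3 `COc1ccc2ncc(S(=O)(=O)c3ccc(OC)c(Cl)c3)c(N3CCC(C)CC3)c2c1` — 21%

All three were run in an assay on isolated protein for displacement of a labelled ligand from metabotropic glutamate receptor 5 (Homo sapiens), with a stated time of 60 min, tested at 1 uM; a higher number here means more inhibition at the concentration tested (going by the name of the read-out), a lower number less inhibition. Compound 2 gives 94% and stands highest of the three readings. Compound 1 gives 33%, a reading beyond the scatter below compound 2. Compound 3 gives 21%, the furthest below compound 2 and also beyond the scatter. Among the measured compounds shown here, no two measured compounds differ in a single place, so no step within the measured set can be isolated, and the spread among them reflects several simultaneous changes.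

Compound 4 `CC1CCN(c2c(S(=O)(=O)c3ccc(F)cc3)cnc3cc(F)ccc23)CC1` has not yet been measured. It differs from compound 2 in one place:
4-fluorophenyl in place of 3,4-dichlorophenyl on a sulfonyl sulfur
Compound 1 and compound 3 each carry a group other than 3,4-dichlorophenyl on the sulfonyl sulfur, but they also differ from compound 2 elsewhere, so their lower readings give only a loose pointer toward the direction of this change. A fall from compound 2 to compound 4 is expected, most likely beyond the scatter, though the size is uncertain. The expected step is a number 34 percentage points lower from compound 2 to compound 4 (beyond the scatter). Compound 4 is estimated at 60%, with a range from 25% to 88%.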

Compound 4, a percentage reported as inhibition, at one concentration (the size of the read-out at that concentration, not a potency): 74.5%
Compound 4: middle estimate off by 14.5 percentage points, on the low side, and the stated range covers the measured number.
By their numbers in this assay, from the lowest: compound 3; then compound 1; then compound 4; then compound 2.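

In this assay, the position on the sulfonyl sulfur now has its first comparison with the rest of the molecule held constant: 4-fluorophenyl in place of 3,4-dichlorophenyl gives a number 19.5 percentage points lower from compound 2 to compound 4 (beyond the scatter), a modest step. Compound 4 still gives 74.5%, so in this pair, a phenyl ring without either chlorine on the sulfonyl sulfur keeps a substantial reading at the concentration tested, and the 3,4-dichlorophenyl group is not required for it. No supporting data bear on why the reading falls between these two compounds.

The compounds shown leave open how the step divides between removing the chlorines and adding the fluorine, which a phenyl carrying a single chlorine, or a plain phenyl, on the same sulfonyl sulfur in this molecule would help to separate. Going by these compounds, it is also open whether a nitrile or a trifluoromethyl in place of the fluorine would move the reading toward that of compound 2 or further from it, and each reading here is the size of the effect at one concentration, not a potency.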